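From compound 3 to compound 4: a flat series so far

The source may report more compounds than this note shows. Statements on the series, on what has been measured and on what is new or still open speak of the compounds shown alone.

In an ADME assay on NIH3T3 cells (Mus musculus) for cytotoxicity, read by MTT assay, with a stated time of 24 h (a lower number here means a stronger inhibitor, a higher number a weaker inhibitor), compound 1 `COc1cccc(/C=N/NC(=O)CSc2nnc(-c3ccncc3)o2)c1` gives 179000 nM, compound 2 `O=C(CSc1nnc(-c2ccncc2)o1)N/N=C/c1ccccc1F` gives 142000 nM and compound 3 `O=C(CSc1nnc(-c2ccncc2)o1)N/N=C/c1ccc(O)c(O)c1` gives 154000 nM. These three numbers lie within the scatter of each other, so compound 3 holds no separate place among them.

The next structure is compound 4 `O=C(CSc1nnc(-c2ccncc2)o1)N/N=C/C=C/c1ccccc1`, with 2-phenylethenyl in place of 3,4-dihydroxyphenyl on a carbon with a double bond to nitrogen.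

Three measured steps at this same place bear on the change: a 1.3-fold lower number from compound 1 to compound 2 (0.10 log units; within the scatter), a 1.2-fold lower number from compound 1 to compound 3 (0.07 log units; within the scatter) and a 1.1-fold higher number from compound 2 to compound 3 (0.04 log units; within the scatter). Each is within the scatter. None of them brings in 2-phenylethenyl, so the expectation extends these steps to a group not yet measured.

No step beyond the scatter is expected in this assay, in either direction. The expected step is small: a 1.1-fold lower number from compound 3 to compound 4 (0.03 log units; within the scatter). For compound 4 the estimated value is 145000 nM, with an expected range from 80000 nM to 260000 nM.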

Compound 4, half-maximal inhibitory concentration: 160000 nM
Beside the measured number, compound 4's estimate is 1.1-fold (0.04 log units) below it, and the stated range covers the measured number.
By their numbers in this assay, from the lowest: compounds 2, 3, 4 and 1 (each within the scatter of the next).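

In this assay, 2-phenylethenyl, which brings a double bond outside aromatic rings and has no hydrogen-bond donors or acceptors, gives only steps within the scatter against all three earlier groups: a 1.0-fold higher number from compound 3 to compound 4 (0.02 log units; within the scatter), a 1.1-fold higher number from compound 2 to compound 4 (0.05 log units; within the scatter) and a 1.1-fold lower number from compound 1 to compound 4 (0.05 log units; within the scatter). On the carbon with a double bond to nitrogen, the flat picture therefore extends from substituted phenyl groups to a group of a different kind, and exchanging the hydrogen-bond donors and acceptors of 3,4-dihydroxyphenyl for none leaves no readable step. Nothing at hand accounts for this flatness.

From the compounds shown here alone, whether an amine, a carboxylic acid or a longer alkyl chain at this place would give a step beyond the scatter remains open. Also open, going by these compounds, is whether a change to the shared core, rather than to this group, would move the number.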